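Cytotoxicity notes on four related compounds

The compounds below may be only part of what the source reports. "The series", "measured", "known", "first", "only" and "open" are said of these compounds alone.

Measured so far:
- Compound 1 `Cc1ccc2[nH]c(-c3cn(-c4ccccc4)nc3-c3ccc(F)cc3)nc2c1`: in an ADME assay on HaCaT cells (Homo sapiens) for cytotoxicity, read by MTT assay, with a stated time of 48 h (on this read-out lower numbers stand for stronger inhibition and higher numbers for weaker inhibition), compound 1 gives > 50000 nM, which is a limit of the assay rather than a number.
- Compound 2 `O=C(OCc1ccccc1)c1ccc2[nH]c(-c3cn(-c4ccccc4)nc3-c3ccc(F)cc3)nc2c1`: compound 2 gives > 50000 nM, again a limit of the assay.
- Compound 3 `Cc1ccc2[nH]c(-c3cn(-c4ccccc4)nc3-c3ccc(Cl)cc3)nc2c1`: compound 3 gives > 50000 nM, also a limit of the assay.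

The change from compound 1 to compound 2 is benzyloxycarbonyl in place of methyl on an aromatic carbon. Its step in this assay, a step that the two limits leave unreadable from compound 1 to compound 2, cannot be sized, because of the limit of > 50000 nM in this assay, at which 3 of the 3 values shown sit. The change from compound 1 to compound 3 is chloro in place of fluoro on an aromatic carbon; its step, a step that the two limits leave unreadable from compound 1 to compound 3, is likewise unreadable for the same reason, (the limit of > 50000 nM in this assay, at which 3 of the 3 values shown sit).

The unmeasured compound 4 `O=C(OCc1ccccc1)c1ccc2[nH]c(-c3cn(-c4ccccc4)nc3-c3ccc(Cl)cc3)nc2c1` differs from compound 3 by benzyloxycarbonyl in place of methyl on an aromatic carbon. This is the same change as that from compound 1 to compound 2, applied to a core that differs from the core of compound 1 by the change already described. The two cores therefore differ only at the halogen, as given above.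

For compound 4 the step that the limit leaves unreadable from compound 3 to compound 4 is expected to be flat, since compound 2 shows > 50000 nM and compound 3 shows > 50000 nM. Compound 4 is accordingly estimated at 80000 nM, with a range from 40000 nM to 200000 nM, most likely reported as a limit.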

Compound 4, half-maximal inhibitory concentration: > 50000 nM
Compound 4 gave a limit, no number; the forecaster's own chance of this, stated with the estimate: 85%; the middle value lies beyond the limit too.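

In this assay compound 4 gives > 50000 nM as a limit of the assay and not a number. No new step can be read, either from compound 3 to compound 4 or from compound 2 to compound 4: (the limit of > 50000 nM in this assay, at which 4 of the 4 values shown sit). The compounds shown leave open whether benzyloxycarbonyl in place of methyl, or chloro in place of fluoro, changes the result in this assay at all.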